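The source may hold more compounds than are shown below. What is called first, only, known or untested is meant among the compounds shown, and "the series" means these compounds.

Working notes on the series. Compound 1 `COc1ccccc1/C=c1/[nH]c(=O)/c(=C\c2cccc(Cl)c2Cl)[nH]c1=O` lacks the allyl present on the others, and in a functional assay on BGC-823 cells (Homo sapiens) for cytotoxicity, read by CCK-8 assay, with a stated time of 72 h (a lower number here means a stronger inhibitor, a higher number a weaker inhibitor), compound 1 gives "not active" (no number reported). Compound 2 `C=CCn1c(=O)/c(=C\c2cccc(F)c2)[nH]c(=O)/c1=C\c1ccccc1OC` and compound 3 `C=CCn1c(=O)/c(=C\c2cccc(Cl)c2Cl)[nH]c(=O)/c1=C\c1ccccc1OC` both carry the allyl on the shared core and differ only in the aryl group on a double-bonded chain carbon bound to an aromatic carbon. In this assay compound 2 gives 5600 nM, while compound 3 gives 2200 nM, the lowest of the two reported numbers; the single-change step a 2.5-fold lower number from compound 2 to compound 3 (0.41 log units; beyond the scatter) is the only one available. Compound 4 `C=CCn1c(=O)/c(=C\c2ccccc2C(F)(F)F)[nH]c(=O)/c1=C\c1ccccc1OC` is not yet measured and differs from compound 3 by 2-(trifluoromethyl)phenyl in place of 2,3-dichlorophenyl on a double-bonded chain carbon bound to an aromatic carbon. Among the measured compounds shown here, the one step that bears on this change swaps the aryl group on a double-bonded chain carbon bound to an aromatic carbon and was modest. Nothing in the set tests 2-(trifluoromethyl)phenyl itself, so no direction beyond the scatter is expected. The step of a 1.6-fold higher number from compound 3 to compound 4 (0.20 log units; within the scatter) is expected to be small. The estimate for compound 4 in this assay is 3500 nM, within 1500 nM to 8000 nM.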

Compound 4, half-maximal inhibitory concentration: 5100 nM
Estimate against measurement, compound 4: 1.5-fold (0.16 log units) below; measured number inside the range.
By their numbers in this assay, from the lowest: compound 3; then compounds 4 and 2 (each within the scatter of the next).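

In this assay, the aryl group on a double-bonded chain carbon bound to an aromatic carbon now has three readings, and a 2.3-fold higher number from compound 3 to compound 4 (0.37 log units; beyond the scatter) gives a second step beyond the scatter away from the 2,3-dichlorophenyl compound. By contrast, a 1.1-fold lower number from compound 2 to compound 4 (0.04 log units; within the scatter) stays within the scatter, so 2-(trifluoromethyl)phenyl and 3-fluorophenyl cannot be told apart here, and only the 2,3-dichlorophenyl group stands out among the three at this position. No measurement in hand accounts for this difference.

The compounds shown leave open whether chlorine itself or the two-substituent pattern of 2,3-dichlorophenyl goes with the lower number, as the set holds neither an unsubstituted phenyl nor a phenyl with one chlorine at this place. Also open, going by these compounds, is how a longer chain in place of the allyl would read with the 2,3-dichlorophenyl group kept.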